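A Hydroxylated Benzyl Variant on the Nucleoside Core

The compounds below may be only part of what the source reports. "The series", "measured", "known", "first", "only" and "open" are said of these compounds alone.

Going by the values given here, compound 1 `OC[C@H]1O[C@@H](n2cnc3c(NCc4ccc(F)cc4)ncnc32)[C@H](O)[C@@H]1O` is the only member of this small set with a measured number in a functional assay on HOS cells (Homo sapiens) for antiproliferative activity, with a stated time of 72 h; on this read-out higher numbers stand for weaker inhibition and lower numbers for stronger inhibition: compound 1 gives 13200 nM. Compound 2 `Cc1cccc(CNc2ncnc3c2ncn3[C@@H]2O[C@H](CO)[C@@H](O)[C@H]2O)c1` reaches only the limit of the assay, and for compound 2 the result is > 166000 nM. Compound 3 `OC[C@H]1O[C@@H](n2cnc3c(NCc4ccc(F)c(Cl)c4)ncnc32)[C@H](O)[C@@H]1O` likewise reaches only a limit, with compound 3 reported as > 166000 nM. Both of these results belong to the limit of > 166000 nM in this assay, at which 2 of the 3 values shown sit.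

Compound 4 `Cc1cccc(CNc2ncnc3c2ncn3[C@@H]2O[C@H](CO)[C@@H](O)[C@H]2O)c1O` has not yet been measured in this assay. It differs from compound 1 by 2-hydroxy-3-methylphenyl in place of 4-fluorophenyl on a saturated chain carbon bound to a nitrogen on an aromatic ring. Among the compounds with values here, two measured steps bear on this change. Exchanging the aryl group alone gave an at least 12-fold higher number from compound 1 to compound 2 (1.09 log units; beyond the scatter). Placing chloro in place of hydrogen on an aromatic carbon of the 4-fluorophenyl of compound 1 gave an at least 12-fold higher number from compound 1 to compound 3 (1.09 log units; beyond the scatter). Between the two weaker compounds, a step that the two limits leave unreadable from compound 2 to compound 3. Within the data shown here, compound 4 carries the 3-methylphenyl pattern of compound 2 with an added hydroxyl, and nothing among the measured compounds shows what that hydroxyl contributes.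

Compound 4 is therefore expected to land near the limit of the assay, with an expected step of an 11-fold higher number from compound 1 to compound 4 (1.06 log units; beyond the scatter). Compound 4 is estimated at 150000 nM, within a range from 40000 nM to 600000 nM.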

Compound 4, half-maximal inhibitory concentration: > 166000 nM
Compound 4: no number, only a limit; the forecaster's own chance of this, stated with the estimate: 70%; middle value at least 1.1-fold (0.04 log units) from the limit.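

In this assay, the 2-hydroxy-3-methylphenyl group on a saturated chain carbon bound to a nitrogen on an aromatic ring also leaves the compound at the limit, with an at least 12-fold higher number from compound 1 to compound 4 (1.09 log units; beyond the scatter). Compound 4 shows that adding a hydroxyl to the 3-methylphenyl pattern of compound 2 does not yield a measurable number, so three different aryl groups at this position now end at a limit, and only the 4-fluorophenyl of compound 1 gives a number: the limit of > 166000 nM in this assay, at which 3 of the 4 values shown sit. Going by these compounds, the steps among compound 2, compound 3 and compound 4 each join two limits and cannot be read, so any effect of the hydroxyl beyond the limit remains unknown.

The compounds shown leave open whether any other group at this position would give a measurable number, such as a plain benzyl, a longer chain such as 2-phenylethyl, or a benzyl carrying an amine. They also leave open how far compound 2, compound 3 and compound 4 lie beyond the limit, and so whether they differ from one another at all.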